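The source may hold more compounds than are shown below. What is called first, only, known or untested is meant among the compounds shown, and "the series" means these compounds.

Compound 3 `CC(CCNC(=O)c1c(Cl)cncc1Cl)N1CCC(C(Oc2cccc(Cl)n2)c2ccc(C(F)(F)F)cc2)CC1` stands at the edge of what an ADME assay on PBMC cells (Homo sapiens) for cytotoxicity (a lower number here means that less compound is tolerated, a higher number that more compound is tolerated), can report. In this assay compound 3 gives > 32500 nM, which is a limit of the assay and not a measured number (the limit of > 32500 nM in this assay, at which 1 of the 3 values shown sits). Compound 1 `CC(CCNC(=O)c1c(Cl)cncc1Cl)N1CCC(C(Oc2ncccc2Cl)c2ccc(C(F)(F)F)cc2)CC1` gives 16700 nM in this assay. Compound 2 `CC(CCNC(=O)c1c(Cl)cncc1Cl)N1CCC(C(Oc2ccc(C(F)(F)F)cc2)c2ccc(C(F)(F)F)cc2)CC1` gives 3100 nM in this assay. The two steps that lead to compound 3 both exchange the whole aryl group on the oxygen: an at least 1.9-fold higher number from compound 1 to compound 3 (0.28 log units; that floor lies within the scatter), whereas an at least 10-fold higher number from compound 2 to compound 3 (1.02 log units; beyond the scatter). Compound 4 `CC(CCNC(=O)c1c(Cl)cncc1Cl)N1CCC(C(Oc2cccc(C#N)n2)c2ccc(C(F)(F)F)cc2)CC1` differs from compound 3 in a smaller way, (cyano in place of chloro on an aromatic carbon). For the measured compounds named here, none of the measured steps exchanges one substituent on the aryl ring for another, so the measured set gives no direction for this change. Since compound 3 already sits at the limit, a half-maximal cytotoxic concentration close to that limit is expected for compound 4. The step of an at least 1.0-fold lower number from compound 3 to compound 4 (0.03 log units; that floor lies within the scatter) is expected to stay within the scatter. Compound 4 is estimated at 30000 nM, ranging from 12000 nM to 70000 nM, with a real chance that only a limit is reported once more.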

Compound 4, half-maximal cytotoxic concentration: 15700 nM
Beside the measured number, compound 4's estimate is 1.9-fold (0.28 log units) above it; measured number inside the range.
By their numbers in this assay, from the lowest: compound 2; then compounds 4 and 1 (each within the scatter of the next). At a limit, above all of these: compound 3.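

In this assay, for the compounds shown here, the exchange of chloro for cyano, next to the ring nitrogen, gives the first measured change of a single substituent on this ring, and it moves the number beyond the scatter: an at least 2.0-fold lower number from compound 3 to compound 4 (0.31 log units; beyond the scatter). The reading for compound 3 is a limit of the assay and not a number, so this step gives only a floor for the size of the change: the limit of > 32500 nM in this assay, at which 1 of the 4 values shown sits. Among the groups on the oxygen, 6-cyanopyridin-2-yl stays well clear of 4-(trifluoromethyl)phenyl, a 5.1-fold higher number from compound 2 to compound 4 (0.70 log units; beyond the scatter), but cannot be told apart from 3-chloropyridin-2-yl, a 1.1-fold lower number from compound 1 to compound 4 (0.03 log units; within the scatter).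

The compounds shown leave open whether a methoxy group or an amine in this place would behave like chloro or like cyano. They also leave open whether the same exchange on the 3-chloropyridin-2-yl group would give a step of similar size.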